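The source may report more compounds than this note shows. Statements on the series, on what has been measured and on what is new or still open speak of the compounds shown alone.

Among the measured compounds shown here, in a functional assay on MDA-MB-231 cells (Homo sapiens) for cytotoxicity, read by MTT assay, with a stated time of 38 h (a higher number here means a weaker inhibitor, a lower number a stronger inhibitor), compound 2 `COc1cc(OC)c2c(=O)c(OCCCN3CCN(C)CC3)c(-c3cc(OC)c(OC)c(OC)c3)oc2c1` gives 30100 nM, the higher of the two numbers measured so far, while compound 1 `COc1cc(OC)c2c(=O)c(OCCCCN3CCCC3)c(-c3cc(OC)c(OC)c(OC)c3)oc2c1` gives 10400 nM. For the measured compounds named here, the only measured step, a 2.9-fold higher number from compound 1 to compound 2 (0.46 log units; beyond the scatter), is modest. Compound 3 `COc1cc(OC)c2c(=O)c(OCC(=O)N/N=C/c3ccc[nH]3)c(-c3cc(OC)c(OC)c(OC)c3)oc2c1` departs from compound 2 in a different way, on a saturated chain carbon bound to an oxygen on an aromatic ring: a group of 10 heavy atoms (6 carbon, 3 nitrogen, 1 oxygen; one five-membered aromatic ring with 1 hetero atom) in place of a group of 9 heavy atoms (7 carbon, 2 nitrogen; one six-membered non-aromatic ring with 2 hetero atoms), on a saturated chain carbon bound to an oxygen on an aromatic ring. Neither measured compound carries a five-membered aromatic ring, so that single step bears on this change only loosely, as a guide to size. With compound 2 at 30100 nM, the expectation leans toward a lower number, though the direction has little support. The step expected in this assay is of similar modest size, a 2.5-fold lower number from compound 2 to compound 3 (0.40 log units; beyond the scatter). Compound 3 is estimated at 12000 nM, with an expected range from 3000 nM to 45000 nM.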

Compound 3, half-maximal inhibitory concentration: 3750 nM
Compound 3: the middle estimate sits 3.2-fold (0.51 log units) above what was measured, within the range that was stated.
By their numbers in this assay, from the lowest: compound 3; then compound 1; then compound 2.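

In this assay, the place on a saturated chain carbon bound to an oxygen on an aromatic ring also accepts a group with a five-membered aromatic ring and no saturated ring, and this change gives the lowest of the three numbers: an 8.0-fold lower number from compound 2 to compound 3 (0.90 log units; beyond the scatter), and a 2.8-fold lower number from compound 1 to compound 3 (0.44 log units; beyond the scatter). The entering group also brings two hydrogen-bond donors and two double bonds outside aromatic rings, so several features change in a single step. No supporting evidence bears on why the number falls.

The compounds shown leave open which of these features goes with the lower number, as all of them change together. A phenyl ring in place of the five-membered aromatic ring, or a morpholine on the chain in place of the 4-methylpiperazin-1-yl group, would begin to separate them.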